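The source may hold more compounds than are shown below. What is called first, only, known or untested is meant among the compounds shown, and "the series" means these compounds.

Compound 1 `COc1ccc(C(=O)/C(=C/c2ccc(Cl)cc2Cl)CCOC(C)=O)cc1` gives 83400 nM in a functional assay on MCF7 cells (Homo sapiens) for inhibition, read by XTT assay, with a stated time of 48 h; a higher number here means a weaker inhibitor, a lower number a stronger inhibitor. Compound 2 `COc1ccc(C(=O)/C(=C/c2ccc(Cl)cc2Cl)CN(C)C(=O)c2ccccc2)cc1` reaches only > 100000 nM in this assay, which is a limit of the assay rather than a measured number. The step of an at least 1.1-fold higher number from compound 1 to compound 2 (0.07 log units; that floor lies within the scatter) can therefore not be sized further, since one of the pair sits at the limit of > 100000 nM in this assay, at which 1 of the 2 values shown sits. Compound 3 `COc1ccc(C(=O)/C(=C/C2CCCCC2)CN(C)C(=O)c2ccccc2)cc1` differs from compound 2 by cyclohexyl in place of 2,4-dichlorophenyl on a double-bonded chain carbon bound to a double-bonded chain carbon. Within the data shown here, no measured step touches this place, and compound 2 already stands at the limit, so no direction beyond the scatter is expected for a number no higher from compound 2 to compound 3 (the limit leaves the size open). Compound 3 is thus estimated at 100000 nM, within 30000 nM to 300000 nM, probably again reported only as a limit.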

Compound 3, half-maximal inhibitory concentration: 32700 nM
Compound 3: the middle estimate sits 3.1-fold (0.49 log units) above what was measured, and the stated range covers the measured number.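

Among these compounds, this is the first measured change at this place, and in this assay it moves the number beyond the usual scatter (an at least 3.0-fold lower number from compound 2 to compound 3 (0.48 log units; beyond the scatter)). With the benzoyl(methyl)amino side unchanged, cyclohexyl gives a stronger inhibitor than 2,4-dichlorophenyl on this double-bonded chain carbon. The step has only a floor, because compound 2 stands at a limit of the assay: the limit of > 100000 nM in this assay, at which 1 of the 3 values shown sits.

The swap removes the chlorines and the aromatic ring at once, so either change could account for the difference. A plain phenyl ring here would separate the two.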